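Benzyl in Place of the Urea on the Shared Core

The source may hold more compounds than are shown below. What is called first, only, known or untested is meant among the compounds shown, and "the series" means these compounds.

Compound 1 `CC(=O)NC1Cc2ccc(NC(=O)c3ccccc3-c3ccc(C(F)(F)F)cc3)cc2C1`: 120 nM
Compound 2 `O=C(NC1Cc2ccc(NC(=O)c3ccccc3-c3ccc(C(F)(F)F)cc3)cc2C1)c1ccccc1`: 270 nM
Compound 3 `CN(C)C(=O)NC1Cc2ccc(NC(=O)c3ccccc3-c3ccc(C(F)(F)F)cc3)cc2C1`: 120 nM

The three measured compounds share one core and differ only in the group on the amine nitrogen. In an assay for inhibition of apolipoprotein B-100 (Homo sapiens), tested at 100 nM (on this read-out higher numbers stand for weaker inhibition and lower numbers for stronger inhibition), compound 3 stands level with compound 1 at the digits printed, together the lowest of the three numbers, and the furthest from it is compound 2: a 2.3-fold lower number from compound 2 to compound 3 (0.35 log units; beyond the scatter). Between the two lowest, no change at the digits printed from compound 1 to compound 3 (within the scatter), so the acetyl and the dimethylcarbamoyl groups cannot be told apart here.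

Compound 4 `O=C(Nc1ccc2c(c1)CC(NCc1ccccc1)C2)c1ccccc1-c1ccc(C(F)(F)F)cc1` is not yet measured. Its change from compound 3 is benzyl in place of dimethylcarbamoyl on an amine nitrogen. Among the compounds with values here, no measured step removes the carbonyl from this nitrogen, so no step bears on it directly. The nearest guide is a 2.3-fold higher number from compound 1 to compound 2 (0.35 log units; beyond the scatter), where a larger group on the carbonyl carbon brought a modest increase, and no change at the digits printed from compound 1 to compound 3 (within the scatter), which shows the dimethylcarbamoyl behaving like acetyl. Going by these compounds, a benzyl group is a larger substituent, and a loss of the carbonyl is untested, so a modest step upward in this assay is expected, with a wide range.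

Compound 4 is therefore estimated at 300 nM, between 100 nM and 1000 nM, meaning an expected step of a 2.5-fold higher number from compound 3 to compound 4 (0.40 log units; beyond the scatter).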

Compound 4, half-maximal inhibitory concentration: 340 nM
Beside the measured number, compound 4's estimate is 1.1-fold (0.05 log units) below it, within the range that was stated.
By their numbers in this assay, from the lowest: compounds 1 and 3 (each within the scatter of the next); then compounds 2 and 4 (each within the scatter of the next).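

Within the data shown here, compound 4 is the only compound here with no carbonyl on the amine nitrogen, and in this assay its benzyl group separates it from the two lowest numbers (a 2.8-fold higher number from compound 3 to compound 4 (0.45 log units; beyond the scatter); a 2.8-fold higher number from compound 1 to compound 4 (0.45 log units; beyond the scatter)), so losing the carbonyl and adding the ring together cost only a modest step. The closer comparison is with benzoyl, which differs from benzyl by the carbonyl: the two cannot be told apart (a 1.3-fold higher number from compound 2 to compound 4 (0.10 log units; within the scatter)), so on this nitrogen the carbonyl shows no effect of its own once a phenyl ring is present. Across all four compounds, the two groups carrying a six-membered aromatic ring stand apart from acetyl and dimethylcarbamoyl, with no compound going against this, though nothing here gives a reason for the pattern.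

The compounds shown leave open whether that separation follows the aromatic ring itself or simply the larger group, a question that a small alkyl such as methyl or ethyl on this nitrogen, or the free primary amine, would address. They also leave open how substituents on the benzyl ring, such as a methoxy group or a carboxylic acid, would read in this assay.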